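Adding 4-cyanobenzyl to compound 3

The source may hold more compounds than are shown below. What is called first, only, known or untested is meant among the compounds shown, and "the series" means these compounds.

Compound 1 `CCN(CC)Cc1cc(Nc2nc3ccccc3n2Cc2ccc(C(F)(F)F)cc2)ccc1O`: 17500 nM
Compound 2 `CCN(CC)Cc1ccc(C)c(Nc2nc3ccccc3n2Cc2ccc(C#N)cc2)c1O`: > 50000 nM, a limit of the assay
Compound 3 `CCN(CC)Cc1cc(Nc2nc3ccccc3[nH]2)ccc1O`: > 50000 nM, a limit of the assay

All three compounds were tested in an ADME assay on CHO cells (Cricetulus griseus) for inhibition, read by MTT assay; on this read-out lower numbers stand for stronger inhibition and higher numbers for weaker inhibition. Compound 3 gives no actual number, only a limit, so it stands at the limit of > 50000 nM in this assay, at which 2 of the 3 values shown sit.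

Compound 4 `CCN(CC)Cc1cc(Nc2nc3ccccc3n2Cc2ccc(C#N)cc2)ccc1O` has not yet been measured. It differs from compound 3 by 4-cyanobenzyl in place of hydrogen on an aromatic nitrogen.

Going by the values given here, one measured step bears directly on this change. It is an at least 2.8-fold higher number from compound 1 to compound 3 (0.45 log units; beyond the scatter), with hydrogen in place of 4-(trifluoromethyl)benzyl on an aromatic nitrogen. As far as these compounds go, its true size is unknown, since one end is a limit. Read in reverse, this step suggests that adding such a group could lower the number in this assay.

Compound 2 goes against that reading: it also carries 4-cyanobenzyl, yet its > 50000 nM is a limit. A modest drop is therefore expected, and the result could well stay at the limit.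

The expected change is an at least 1.6-fold lower number from compound 3 to compound 4 (0.22 log units; that floor lies within the scatter).

Compound 4 is estimated at 30000 nM, with an expected range from 12000 nM to 50000 nM.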

Compound 4, half-maximal inhibitory concentration: > 50000 nM
Compound 4: a limit, no number; the forecaster's own chance of this, stated with the estimate: 40%; at least 1.6-fold (0.22 log units) between middle value and limit.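

In this assay, as far as these compounds go, cyano in place of trifluoromethyl on the benzyl group gives an at least 2.8-fold higher number from compound 1 to compound 4 (0.45 log units; beyond the scatter), and its true size is unknown, as compound 4 holds a limit and not a number. With the rest of the structure unchanged, this shows that a benzyl group on this aromatic nitrogen is not enough on its own to bring the value of compound 1 within the assay's range: the group carried on that benzyl ring also matters. The step from compound 3 to compound 4 cannot be read, since both ends are limits: the limit of > 50000 nM in this assay, at which 3 of the 4 values shown sit.

Still open, from the compounds shown here alone, is whether a plain benzyl, a 4-chlorobenzyl or a 4-methoxybenzyl on this nitrogen would give a measurable number, as compound 1 does, or stay at the limit, as compound 4 does. Also open is how far compound 3 and compound 4 lie from each other, since no actual number exists for either: the limit of > 50000 nM in this assay, at which 3 of the 4 values shown sit.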